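The compounds below may be only part of what the source reports. "The series", "measured", "known", "first", "only" and "open" are said of these compounds alone.

Measured in a functional assay on KB cells (Homo sapiens) for inhibition; on this read-out higher numbers stand for weaker inhibition and lower numbers for stronger inhibition:
Compound 1 `Nc1nc2cc(Cl)c(Cl)cc2n1Cc1ccccc1`: 170000 nM
Compound 2 `Clc1cc2nc(Cl)n(Cc3ccccc3)c2cc1Cl`: > 100000 nM, a limit
Compound 3 `CC(C)(C)c1ccc(Cn2c(Cl)nc3cc(Cl)c(Cl)cc32)cc1`: > 100000 nM, a limit

Compound 2 has no number, only a limit of > 100000 nM.

Compound 4 `Clc1cc2nc(Cl)n(Cc3ccccc3Cl)c2cc1Cl` differs from it in one place: chloro in place of hydrogen on an aromatic carbon.

Within the data shown here, two measured steps bear on this change. The closer is a step that the two limits leave unreadable from compound 2 to compound 3, which also replaces hydrogen on an aromatic carbon. The other is a step that the limit leaves unreadable from compound 1 to compound 2. Neither has a readable size, and the series sits at the limit of > 100000 nM in this assay, at which 2 of the 3 values shown sit. No direction can therefore be argued, and no change beyond the scatter is expected in this assay.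

The expected step is a step that the limit leaves unreadable from compound 2 to compound 4.

For compound 4 the estimated value is 130000 nM, with an expected range of 50000 nM to 300000 nM.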

Compound 4, half-maximal inhibitory concentration: 156000 nM
Beside the measured number, compound 4's estimate is 1.2-fold (0.08 log units) below it; low and high end bracket the measured number.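

Among these compounds, compound 2 stands only as a limit, > 100000 nM, and no step between compound 2 and compound 4 can be read. The compounds shown leave open whether chloro in place of hydrogen on an aromatic carbon changes inhibition at all.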